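Growth inhibition notes: from compound 1 toward compound 4

The source may report more compounds than this note shows. Statements on the series, on what has been measured and on what is new or still open speak of the compounds shown alone.

Measured compounds:
compound 1 `O=CN1CCN(c2ccc(Cl)cc2)C1=S`: 14200 nM
compound 2 `N#C/C(=C\N1CCN(C(=O)c2ccco2)C1=S)C(N)=O`: 24000 nM
compound 3 `COc1cc(C(=O)N2CCN(C=O)C2=S)cc(OC)c1OC`: 21900 nM

All three values come from a functional assay on IGROV-1 cells (Homo sapiens) for inhibition, read by sulforhodamine B assay, with a stated time of 48 h; on this read-out higher numbers stand for weaker inhibition of growth and lower numbers for stronger inhibition of growth. Compound 1 carries the lowest number of the three, but the values of compound 3 and compound 2 both lie within the scatter of repeated measurement, so no order among the three can be claimed and none of them can be called more or less active than another. No pair of these compounds differs in one place only, so the series so far gives no measured step to build on.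

Compound 4 `O=CN1CCN(c2ccc(Cl)c(Cl)c2)C1=S` is the next compound, not yet measured in this assay. Relative to compound 1 it carries chloro in place of hydrogen on an aromatic carbon. For the measured compounds named here, the series holds no measured step at this position, so the expected step in this assay is a 1.3-fold lower number from compound 1 to compound 4 (0.11 log units; within the scatter), small and within the usual scatter, leaning if anything toward a lower number. Compound 4 is estimated at 11000 nM in this assay, with a range from 4000 nM to 30000 nM.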

Compound 4, concentration for 50% growth inhibition: 15100 nM
Beside the measured number, compound 4's estimate is 1.4-fold (0.14 log units) below it, within the range that was stated.
By their numbers in this assay, from the lowest: compounds 1, 4, 3 and 2 (each within the scatter of the next).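

The series now has its first measured step. In this assay, chloro in place of hydrogen on an aromatic carbon, ortho to a chloro group and meta to a group of 8 heavy atoms, gives a 1.1-fold higher number from compound 1 to compound 4 (0.03 log units; within the scatter) and stays within the scatter, so compound 1 and compound 4 cannot be told apart on this read-out. This place on the aromatic ring therefore tolerates this one added chloro, though a single step says nothing about other groups there, and no separate measurement bears on the result.

On these data alone, whether a methoxy group, an amine or a carboxylic acid at this same place would give a step beyond the scatter remains open. Also open, as far as these compounds go, is what hydrogen in place of the chloro group already present on compound 1 would give.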